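The source may report more compounds than this note shows. Statements on the series, on what has been measured and on what is new or still open speak of the compounds shown alone.

In a functional assay on A549 cells (Homo sapiens) for cytotoxicity, read by MTT assay, with a stated time of 72 h (a lower number here means a stronger inhibitor, a higher number a weaker inhibitor), compound 1 `CN(C)CCn1cnnc1-c1cc(Oc2ccc(NC(=O)N/N=C/c3ccc(Cl)cc3Cl)cc2F)ccn1` gives 810 nM. Compound 2 `CN(C)CCn1cnnc1-c1cc(Oc2ccc(NC(=O)N/N=C/c3cc(Br)c(O)c(Br)c3)cc2F)ccn1` gives > 100000 nM, which is a limit of the assay rather than a measured number. Compound 2 therefore stands at the limit of > 100000 nM in this assay, at which 1 of the 2 values shown sits. Between the two measured compounds a single aryl group was exchanged for another, and the result was an at least 120-fold higher number from compound 1 to compound 2 (2.09 log units; beyond the scatter). Compound 3 `CN(C)CCn1cnnc1-c1cc(Oc2ccc(NC(=O)N/N=C/c3ccc(O)c(F)c3)cc2F)ccn1` moves on from compound 2 by a further exchange: 3-fluoro-4-hydroxyphenyl in place of 3,5-dibromo-4-hydroxyphenyl on a carbon with a double bond to nitrogen. The hydroxyl stays, the two bromines give way to a single fluorine. Among the compounds with values here, only the step from compound 1 to compound 2 has any bearing, and it combined the arrival of a hydroxyl with a changed halogen pattern, so it fixes no size for a halogen change on its own. Some recovery of potency is expected, but not a full return. The estimate for compound 3 is 20000 nM, within a range from 3000 nM to 150000 nM. That expected change amounts to an at least 5.0-fold lower number from compound 2 to compound 3 (0.69 log units; beyond the scatter).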

Compound 3, half-maximal inhibitory concentration: 13400 nM
Estimate against measurement, compound 3: 1.5-fold (0.17 log units) above; measured number inside the range.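

In this assay, the exchange of 3,5-dibromo-4-hydroxyphenyl for 3-fluoro-4-hydroxyphenyl gives an at least 7.4-fold lower number from compound 2 to compound 3 (0.87 log units; beyond the scatter), so a hydroxyl-bearing aryl group on this carbon can keep measurable activity, and the halogens alone can change the result with the hydroxyl held in place. The size of that step is only a lower bound, as compound 2 is held at a limit of the assay and not at a measured number: the limit of > 100000 nM in this assay, at which 1 of the 3 values shown sits. Even so, 3-fluoro-4-hydroxyphenyl does not match 2,4-dichlorophenyl, with a 17-fold higher number from compound 1 to compound 3 (1.22 log units; beyond the scatter).

The compounds shown do not separate the part of that loss tied to the hydroxyl from the part tied to the halogen pattern. A methoxy group or an amine in place of the hydroxyl, on an otherwise unchanged 3-fluorophenyl group, would bear directly on that question.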